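Swapping methoxy for isopropyl in a cytotoxicity series

The source may hold more compounds than are shown below. What is called first, only, known or untested is meant among the compounds shown, and "the series" means these compounds.

Of the compounds shown here, three have been measured in an ADME assay on HEK293 cells (Homo sapiens) for cytotoxicity, read by MTT assay, with a stated time of 48 h; on this read-out lower numbers stand for stronger inhibition and higher numbers for weaker inhibition. Compound 1 `O=C1CS/C(=N/c2ccccc2)N1Cc1ccncc1` gives 99500 nM. Compound 2 `O=C1/C(=C\c2ccccc2)S/C(=N/c2ccccc2)N1Cc1ccncc1` gives 64700 nM. Compound 3 `COc1ccc(/C=C2/S/C(=N/c3ccccc3)N(Cc3ccncc3)C2=O)cc1` gives 47900 nM. Compound 3 thus stands under compound 1 by more than the usual scatter, but its value cannot be told apart from that of compound 2.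

The next compound is compound 4 `CC(C)c1ccc(/C=C2/S/C(=N/c3ccccc3)N(Cc3ccncc3)C2=O)cc1`, which carries isopropyl in place of methoxy on an aromatic carbon, para to a large group: isopropyl in place of methoxy on an aromatic carbon. The same difference, cut one bond further out, reads 4-methoxyphenyl to 4-isopropylphenyl. Among the compounds with values here, no measured compound carries isopropyl, so the data offer no direct guide to this group. Within the data shown here, the one measured step that bears on the change is a 1.4-fold lower number from compound 2 to compound 3 (0.13 log units; within the scatter), methoxy in place of hydrogen on an aromatic carbon. Among the measured compounds shown here, with that small step as the only guide, no change beyond the scatter is expected in this assay, in either direction. The expected step is a 1.1-fold lower number from compound 3 to compound 4 (0.03 log units; within the scatter). Compound 4 is estimated at 45000 nM, with an expected range from 21000 nM to 95000 nM.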

Compound 4, half-maximal inhibitory concentration: 137000 nM
Compound 4: the middle estimate sits 3.0-fold (0.48 log units) below what was measured; the measured number lies above the stated range.
By their numbers in this assay, from the lowest: compounds 3, 2, 1 and 4 (each within the scatter of the next, the first and the last beyond it).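

In this assay, within the data shown here, the position on an aromatic carbon, para to a large group, turns out not to be indifferent to what sits there: isopropyl in place of methoxy gives a 2.9-fold higher number from compound 3 to compound 4 (0.46 log units; beyond the scatter), the first change at this place that lies beyond the scatter. Isopropyl in place of hydrogen also gives a step beyond the scatter, a 2.1-fold higher number from compound 2 to compound 4 (0.33 log units; beyond the scatter), whereas methoxy in place of hydrogen gave only a 1.4-fold lower number from compound 2 to compound 3 (0.13 log units; within the scatter), which lies within it, so at this place the two groups are not interchangeable in this assay, and the one that carries an oxygen and a hydrogen-bond acceptor is the one that stays level with hydrogen. Nothing measured here accounts for this difference between the two groups.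

On these data alone, whether an ethyl or a tert-butyl group at this place would follow isopropyl, and whether a hydroxyl group or an amine would follow methoxy, remains open. As far as these compounds go, with one compound for each group, it also remains open whether the same swap would give a similar step on a different core.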